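The source may hold more compounds than are shown below. What is called first, only, known or untested is meant among the compounds shown, and "the series" means these compounds.

Measured so far in an ADME assay on L6 cells (Rattus norvegicus) for cytotoxicity, read by resazurin assay, with a stated time of 72 h; a higher number here means that more compound is needed for the effect, a lower number that less compound is needed:
- Compound 1 `CCOC(=O)C1=C(C)N/C(=C/c2cc(C)n(-c3ccc(N(C)C)cc3)c2C)C1=O` gives 180000 nM.
- Compound 2 `CCOC(=O)C1=C(C)N/C(=C/c2cc(C)n(-c3ccc(S(=O)(=O)C(F)(F)F)cc3)c2C)C1=O` gives 120000 nM.
- Compound 3 `CCOC(=O)C1=C(C)N/C(=C/c2cc(C)n(-c3ccc([S+](C)[O-])cc3)c2C)C1=O` gives 220000 nM.

Compound 1 has the second highest of these three numbers. Its nearest neighbour is compound 3, with a 1.2-fold higher number from compound 1 to compound 3 (0.09 log units; within the scatter); its furthest is compound 2, with a 1.5-fold lower number from compound 1 to compound 2 (0.18 log units; within the scatter). The third step, a 1.8-fold higher number from compound 2 to compound 3 (0.26 log units; within the scatter), is likewise within the scatter, so across the three measured compounds nothing moves beyond the usual spread of repeated readings.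

Compound 4 `CCOC(=O)C1=C(C)N/C(=C/c2cc(C)n(Cc3ccccc3)c2C)C1=O` remains to be measured in this assay. Relative to compound 1 the change is: benzyl in place of 4-(dimethylamino)phenyl on an aromatic nitrogen. None of the three measured steps makes a change of this kind; all of them exchange one group for another on an aromatic carbon and leave the group on the aromatic nitrogen untouched. Among the measured compounds shown here, there is therefore no measured step that directly bears on this replacement, and the only guidance is that every change tried so far has stayed within the scatter. On that basis no step beyond the scatter is expected, no change at the digits printed from compound 1 to compound 4 (within the scatter). Compound 4 is accordingly estimated at 180000 nM, with an expected range from 60000 nM to 450000 nM.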

Compound 4, half-maximal effective concentration: 50000 nM
Estimate against measurement, compound 4: 3.6-fold (0.56 log units) above; the whole stated range lies above it.
By their numbers in this assay, from the lowest: compound 4; then compounds 2, 1 and 3 (each within the scatter of the next).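

In this assay, among the compounds shown here, the group on the aromatic nitrogen is the first place where a change goes beyond the scatter: benzyl in place of 4-(dimethylamino)phenyl gives a 3.6-fold lower number from compound 1 to compound 4 (0.56 log units; beyond the scatter), and the corresponding change from the group carried by compound 3 gives a 4.4-fold lower number from compound 3 to compound 4 (0.64 log units; beyond the scatter). The exchanges on an aromatic carbon among compounds 1, 2 and 3 all stayed within the scatter, so the whole group on the nitrogen separates these compounds where the substituent on its phenyl ring did not. Both steps are modest, and no measurement at hand accounts for them.

The compounds shown leave open whether the step follows the added carbon link of benzyl or the loss of the dimethylamino group, which a plain phenyl or a 4-(dimethylamino)benzyl on the aromatic nitrogen would separate. Also open, as far as these compounds go, is how a longer chain, such as phenylethyl, or a simple alkyl group such as methyl would read at this position.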